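What follows from compound 3 to compound 4?

The source may report more compounds than this note shows. Statements on the series, on what has been measured and on what is new or still open speak of the compounds shown alone.

Measured so far in a functional assay on KB cells (Homo sapiens) for antiproliferative activity, read by sulforhodamine B assay, with a stated time of 3 days (on this read-out lower numbers stand for an effect already at smaller amounts and higher numbers for an effect only at larger amounts of compound), are these compounds
- compound 1 `CCC1=C(O)c2c(oc(-c3ccc(OC)cc3)cc2=O)C(CC)(CC)C1=O` gives 17.7 uM
- compound 2 `CCC1=C(O)c2c(oc(-c3ccc(CBr)cc3)cc2=O)C(CC)(CC)C1=O` gives > 46.5 uM (a limit)
- compound 3 `CCC1=C(O)c2c(oc(-c3ccc(O)c(C)c3C)cc2=O)C(CC)(CC)C1=O` gives 6.5 uM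

Of the two exact numbers, compound 3 at 6.5 uM is the lower one. Compound 2 at > 46.5 uM is only a limit. Compound 4 `CCC1=C(O)c2c(oc(-c3ccc(F)c(C)c3)cc2=O)C(CC)(CC)C1=O` carries 4-fluoro-3-methylphenyl in place of 4-hydroxy-2,3-dimethylphenyl on an aromatic carbon of the shared core. Two measured changes of this same group bear on it: one gives a 2.7-fold lower number from compound 1 to compound 3 (0.44 log units; beyond the scatter) and the other at least 7.1-fold lower number from compound 2 to compound 3 (0.85 log units; beyond the scatter) and so both end at the group of compound 3. On those two steps alone, leaving that group is expected to raise the number modestly in this assay rather than leave it unchanged. The expected change is a 2.3-fold higher number from compound 3 to compound 4 (0.36 log units; beyond the scatter) overall. For compound 4 the estimated value is 15 uM with an expected range from 6 uM to 40 uM as the likely span.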

Compound 4, concentration for half-maximal effect: 40.5 uM
Compound 4: middle estimate off by 2.7-fold (0.43 log units), on the low side; the whole stated range lies below it.
By their numbers in this assay, from the lowest: compound 3; then compound 1; then compound 4. At a limit, above all of these: compound 2.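

In this assay, swapping the aryl group on this aromatic carbon of the shared core moves the number beyond the scatter: 4-fluoro-3-methylphenyl in place of 4-hydroxy-2,3-dimethylphenyl gives a 6.2-fold higher number from compound 3 to compound 4 (0.79 log units; beyond the scatter), and in place of 4-methoxyphenyl it gives a 2.3-fold higher number from compound 1 to compound 4 (0.36 log units; beyond the scatter). The entering group carries no hydrogen-bond donor or acceptor, yet this one step changes the hydroxy group, a methyl group and the fluorine together. Compound 2 is only a limit: the limit of > 46.5 uM in this assay, at which 1 of the 4 values shown sits. Against that limit, 4-fluoro-3-methylphenyl in place of 4-(bromomethyl)phenyl gives an at least 1.1-fold lower number from compound 2 to compound 4 (0.05 log units; that floor lies within the scatter), so this step shows no change beyond the scatter.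

Which of those three parts drives the rise stays open. So does how an amine or a carboxylic acid on this phenyl ring would behave.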